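The compounds below may be only part of what the source reports. "The series", "measured", "known", "first", "only" and "open" are said of these compounds alone.

Measured so far:
compound 1 `CNCc1cc(-c2cccnc2F)n(S(=O)(=O)c2cccnc2)c1` gives 96%
compound 2 `CNCc1cn(S(=O)(=O)c2ncccc2C)c(-c2cccnc2F)c1F` gives 54%

In a functional assay on the whole organism (strain Jcl:Sprague-Dawley) for inhibition, with Rattus norvegicus as the target, with stated times of 3 min and 3 h, at a dose of 1 mg/kg by the intravenous route (a lower number here means less inhibition, a higher number more inhibition at the dose given (going by the name of the read-out)), compound 1 gives 96%, whereas compound 2 gives 54%, the lowest of the two numbers and a gap beyond the usual scatter. Among the measured compounds shown here, no step between these two has been worked out, so only the two values themselves speak.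

Compound 3 `CNCc1cn(S(=O)(=O)c2cccnc2C)c(-c2cccnc2F)c1F` has not yet been measured. It differs from compound 2 in one place (2-methylpyridin-3-yl in place of 3-methylpyridin-2-yl on a sulfonyl sulfur). For the measured compounds named here, no similar step has been measured, so the expectation rests on thin ground. A modest rise in this assay is expected, a number 11 percentage points higher from compound 2 to compound 3 (beyond the scatter), though a change within the scatter would not surprise. Compound 3 is estimated at 65%, within 35% to 90%.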

Compound 3, a percentage reported as inhibition, in the whole organism at one dose (the size of the read-out at that dose, not a potency): 92%
Compound 3: middle estimate off by 27 percentage points, on the low side, and the stated range ends below it.
By their numbers in this assay, from the lowest: compound 2; then compounds 3 and 1 (each within the scatter of the next).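

On the sulfonyl sulfur, 2-methylpyridin-3-yl in place of 3-methylpyridin-2-yl gives a number 38 percentage points higher from compound 2 to compound 3 (beyond the scatter) in this assay, although the two groups hold the same atoms, joined differently. This position is therefore sensitive to the arrangement of those atoms, not only to which atoms are present. Nothing available here explains why this rearrangement matters so much. Still open, going by these compounds, is whether the higher value depends on the methyl group, or whether a methoxy group or a chlorine atom in its place would give a similar value. A plain phenyl ring on the sulfonyl sulfur would show what the ring nitrogen contributes.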